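Swapping chloro for methyl on compound 2

This account rests on a few compounds, and the source may have more. Where it says the series, first, only, none or still open, it means among the compounds named here.

Measured so far in a functional assay on thoracic aorta (Rattus norvegicus, strain Wistar), with a stated time of 15 min (on this read-out higher numbers stand for an effect only at larger amounts of compound and lower numbers for an effect already at smaller amounts), are these compounds:
compound 1 `CC(NC(=O)NS(=O)(=O)c1ccc(Cl)cc1)c1cc(Br)ccc1OCc1ccccc1` gives 57500 nM
compound 2 `Cc1ccc(OCc2ccccc2)c(C(C)NC(=O)NS(=O)(=O)c2ccc(Cl)cc2)c1` gives 65300 nM
compound 3 `Cc1ccc(OCc2ccccc2)c(C(C)NC(=O)N(C)S(=O)(=O)c2ccc(Cl)cc2)c1` gives 142000 nM

Compound 2 holds the second highest of the three numbers, with compound 1 nearest to it and compound 3 furthest off. Compound 4 `Cc1ccc(S(=O)(=O)NC(=O)NC(C)c2cc(C)ccc2OCc2ccccc2)cc1` differs from compound 2 by methyl in place of chloro on an aromatic carbon, para to a large group (methyl in place of chloro on an aromatic carbon). Of the measured steps, methyl in place of bromo on an aromatic carbon bears most closely (a 1.1-fold higher number from compound 1 to compound 2 (0.06 log units; within the scatter)). Methyl in place of hydrogen on an amide-type nitrogen is a different kind of change and bears less (a 2.2-fold higher number from compound 2 to compound 3 (0.34 log units; beyond the scatter)). Going by the values given here, no measured compound carries the new change itself. A step within the scatter is therefore expected in this assay here (a 1.0-fold higher number from compound 2 to compound 4 (0.02 log units; within the scatter)). Compound 4 is estimated at 68000 nM (expected range 33000 nM to 140000 nM).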

Compound 4, half-maximal effective concentration: 91900 nM
For compound 4 the middle estimate is 1.4-fold (0.13 log units) below the measured one; low and high end bracket the measured number.
By their numbers in this assay, from the lowest: compounds 1, 2, 4 and 3 (each within the scatter of the next, the first and the last beyond it).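

In this assay, going by these compounds alone, the change from (4-chlorophenyl)sulfonyl to (4-methylphenyl)sulfonyl gives a 1.4-fold higher number from compound 2 to compound 4 (0.15 log units; within the scatter), the first reading at this position, since the earlier steps changed other places in the molecule. Here, as with methyl in place of bromo at the other aromatic site, a single-atom exchange stays within the scatter. Nothing on hand offers an explanation for this result. As far as these compounds go, whether a carboxylic acid, an amine or a longer chain at this position would move the number beyond the scatter remains open. So does whether methyl on the amide-type nitrogen of compound 4 would shift it as it did for compound 2.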